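A few compounds are considered here, and "the series" means these few. Any claim that something is new, unique, unknown or untested is made for them only; others in the source may bear on it.

Compound 3 `Cc1ncnc2c1c(-c1cc3ccccc3o1)cn2[C@@H]1O[C@H](CO)[C@@H](O)[C@H]1O` carries a methyl on the six-membered ring of the shared core. In a functional assay on CEM-DNR-bulk cells (Homo sapiens), read by MTT assay, with a stated time of 72 h (on this read-out lower numbers stand for stronger inhibition and higher numbers for weaker inhibition), compound 3 gives > 20000 nM, which is a limit of the assay and not a number. Compound 1 `CNc1ncnc2c1c(-c1ccccc1)cn2[C@@H]1O[C@H](CO)[C@@H](O)[C@H]1O` gives in this assay > 20000 nM, likewise a limit. Compound 2 `CNc1ncnc2c1c(-c1cccs1)cn2[C@@H]1O[C@H](CO)[C@@H](O)[C@H]1O` gives in this assay > 20000 nM, again a limit. Going by the values given here, the only step between measured neighbours, a step that the two limits leave unreadable from compound 1 to compound 2, cannot be read because both of its ends sit at the limit (the limit of > 20000 nM in this assay, at which 3 of the 3 values shown sit). Compound 4 `CNc1ncnc2c1c(-c1cc3ccccc3o1)cn2[C@@H]1O[C@H](CO)[C@@H](O)[C@H]1O` is compound 3 with the change (methylamino in place of methyl on an aromatic carbon). Among the compounds with values here, no measured step matches this change, and compounds 1 and 2 already carry methylamino at the same place of the core while sitting at the limit. Nothing among the numbers shown points to a reading that falls inside the measurable range. The step is therefore expected to be a number no higher from compound 3 to compound 4 (the limit leaves the size open). Compound 4 is expected at 20000 nM, with a range from 5000 nM to 60000 nM, most probably reported once more only as a limit.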

Compound 4, half-maximal inhibitory concentration: > 20000 nM
Compound 4 ended at the assay's limit; the forecaster's own chance of this, stated with the estimate: 80%; the middle value lies on the limit itself.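

The steps from compounds 1, 2 and 3 to compound 4 cannot be read, as both ends of each are limits and not numbers: the limit of > 20000 nM in this assay, at which 4 of the 4 values shown sit. The compounds shown leave open whether any change at the two varied places on the shared core gives a reading within the measurable range.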